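Swapping Pyrazole for Phenyl on a Cinnamic Acid EP3 Antagonist

The compounds below may be only part of what the source reports. "The series", "measured", "known", "first", "only" and "open" are said of these compounds alone.

Compound 1 `O=C(O)/C=C/c1ccc(Cn2cccn2)cc1OCCc1ccc2ccccc2c1` is the anchor of this set. In an in vitro functional assay on CHO cells for antagonist activity at prostaglandin E2 receptor EP3 subtype (Mus musculus) (a lower number here means a stronger inhibitor, a higher number a weaker inhibitor), compound 1 gives 73 nM, the lowest of the two measured numbers. Compound 3 `O=C(O)/C=C/c1ccc(Cn2ccnc2)cc1OCCCOc1ccccc1` is the nearest of the rest, and in this assay compound 3 gives 3000 nM, a gap that lies beyond the usual scatter. Compound 2 `COc1ccc(/C=C/C(=O)O)c(OCCC2(C)CCc3c(C)c(O)c(C)c(C)c3O2)c1` reaches only a limit in this assay, where compound 2 gives > 10000 nM. Compound 4 `O=C(O)/C=C/c1ccc(Cc2ccccc2)cc1OCCc1ccc2ccccc2c1` is not yet measured. It differs from compound 1 in one place: phenyl in place of 1H-pyrazol-1-yl on a saturated chain carbon bound to an aromatic carbon. Going by the values given here, no measured pair isolates this change, and its size is uncertain. A modest weakening is expected, with an expected step of a 2.7-fold higher number from compound 1 to compound 4 (0.44 log units; beyond the scatter). Compound 4 is estimated at 200 nM in this assay, within a range from 40 nM to 1500 nM.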

Compound 4, half-maximal inhibitory concentration: 400 nM
Beside the measured number, compound 4's estimate is 2.0-fold (0.30 log units) below it; low and high end bracket the measured number.
By their numbers in this assay, from the lowest: compound 1; then compound 4; then compound 3. At a limit, above all of these: compound 2.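

In this assay, going by these compounds alone, this is the first pair differing in one place, and phenyl in place of 1H-pyrazol-1-yl on a saturated chain carbon bound to an aromatic carbon brings a 5.5-fold higher number from compound 1 to compound 4 (0.74 log units; beyond the scatter). A ring of carbon only therefore still gives a measurable number at this position, so the nitrogen atoms of the pyrazole are not required for inhibition, although the pyrazole gives the lower number. Nothing measured here accounts for the size of this step.

This single pair cannot separate the loss of the ring nitrogen atoms from the change in ring size. From the compounds shown here alone, how a morpholine or a dimethylamino group would behave on the same carbon remains open.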